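This account rests on a few compounds, and the source may have more. Where it says the series, first, only, none or still open, it means among the compounds named here.

Compound 2 `Cc1cc(Nc2nc(Nc3ccc(C(=O)NC4CC(C)(C)N([O])C(C)(C)C4)cc3)ncc2F)n[nH]1` is the starting point here. In a functional assay on LoVo cells (Homo sapiens) for antiproliferative activity, read by MTT assay, with a stated time of 48 h (on this read-out lower numbers stand for stronger inhibition and higher numbers for weaker inhibition), compound 2 gives 42200 nM, the highest of the two numbers that are known, with compound 3 nearest. Compound 1 `Cc1cc(Nc2nc(Nc3ccc(C(=O)NC4CC(C)(C)N([O])C(C)(C)C4)cc3)ncc2[N+](=O)[O-])n[nH]1`, which carries a nitro group where compound 2 carries fluoro, reaches only a limit in this assay: compound 1 gives > 100000 nM, a boundary of the assay and not a number. The step of an at least 2.3-fold lower number from compound 1 to compound 2 (0.37 log units; beyond the scatter) therefore can only be stated as a lower bound. Within the data shown here, compound 3 `CC(C)OC(=O)Cc1csc(Nc2nc(Nc3ccc(C(=O)NC4CC(C)(C)N([O])C(C)(C)C4)cc3)ncc2F)n1` replaces the methylpyrazole of compound 2 with a thiazole bearing an ester-tipped chain, and in this assay compound 3 gives 11900 nM, so the step of a 3.5-fold lower number from compound 2 to compound 3 (0.55 log units; beyond the scatter) is the one measured change that moves the number down.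

Compound 4 `CCCCOC(=O)Cc1cc(Nc2nc(Nc3ccc(C(=O)NC4CC(C)(C)N([O])C(C)(C)C4)cc3)ncc2F)n[nH]1` differs from compound 2 by butoxycarbonyl in place of hydrogen on a saturated chain carbon bound to an aromatic carbon. This keeps the pyrazole of compound 2 but adds an ester chain, as the move to compound 3 did, so a modest lowering is expected. Compound 4 is estimated at 18000 nM, within 7000 nM to 45000 nM, an expected step of a 2.3-fold lower number from compound 2 to compound 4 (0.37 log units; beyond the scatter).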

Compound 4, half-maximal inhibitory concentration: 11400 nM
Estimate against measurement, compound 4: 1.6-fold (0.20 log units) above, within the range that was stated.
By their numbers in this assay, from the lowest: compounds 4 and 3 (each within the scatter of the next); then compound 2. At a limit, above all of these: compound 1.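

In this assay, butoxycarbonyl on a saturated chain carbon bound to an aromatic carbon gives a 3.7-fold lower number from compound 2 to compound 4 (0.57 log units; beyond the scatter), so this carbon can carry a much larger group with a lower number as the result. The move to compound 3 replaced the whole ring and its substituent at once, whereas here the pyrazole stays, so this step isolates the effect of adding the ester chain to the ring that was already there. Nothing measured here explains why the number falls.

The compounds shown cannot separate the contribution of the ester from that of the chain's length. A carboxylic acid, an amide or a plain alkyl chain at this same carbon would test whether the ester is needed, and a shorter ester such as a methyl ester would test how much of the chain is.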